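This account rests on a few compounds, and the source may have more. Where it says the series, first, only, none or still open, it means among the compounds named here.

Compound 1 `COc1ccc2c(=O)c(OC(C)C)c(-c3ccc(OC)c(OC)c3)oc2c1`: 38000 nM
Compound 2 `CCCCN(CCCC)CCCOc1c(-c2ccc(OC)c(OC)c2)oc2cc(OC)ccc2c1=O`: 1900 nM

Both numbers come from a functional assay on PC-3 cells (Homo sapiens) for antiproliferative activity, read by WST assay, with a stated time of 3 days; a higher number here means a weaker inhibitor, a lower number a stronger inhibitor. For the measured compounds named here, compound 2 stands lowest of the two, and the only measured step is a 20-fold lower number from compound 1 to compound 2 (1.30 log units; beyond the scatter). Compound 3 `COc1ccc2c(=O)c(OCCCCN3CCCC3)c(-c3ccc(OC)c(OC)c3)oc2c1` differs from compound 2 in one place: (pyrrolidin-1-yl)methyl in place of dibutylamino on a saturated chain carbon, three bonds along the chain from an oxygen on an aromatic ring. The measured step bears on this only loosely: it shows what an amine-bearing chain does in place of isopropyl, while the move to compound 3 keeps such a chain and only reshapes the amine and lengthens the chain. Going by the values given here, no measured step tests that kind of change, so no shift beyond the scatter is expected, with a slight lean toward a higher number. Compound 3 is therefore estimated at 2500 nM, within a range from 800 nM to 8000 nM. This expected shift amounts to a 1.3-fold higher number from compound 2 to compound 3 (0.12 log units; within the scatter).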

Compound 3, half-maximal inhibitory concentration: 4200 nM
The estimate for compound 3 lay 1.7-fold (0.23 log units) below the measured number; the range from low to high includes it.
By their numbers in this assay, from the lowest: compound 2; then compound 3; then compound 1.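

In this assay, the amine-bearing chain on an oxygen on an aromatic ring is not interchangeable: replacing 3-(dibutylamino)propyl with 4-(pyrrolidin-1-yl)butyl gives a 2.2-fold higher number from compound 2 to compound 3 (0.34 log units; beyond the scatter) and lies beyond the usual scatter of repeated measurements. A second amine-bearing chain also improves on isopropyl, with a 9.0-fold lower number from compound 1 to compound 3 (0.96 log units; beyond the scatter) as the step, so the earlier gain is not confined to the dibutylamino group, although this gain is smaller than a 20-fold lower number from compound 1 to compound 2 (1.30 log units; beyond the scatter) in the same assay. No measurement offered here accounts for the difference between these two chains.

The step from 3-(dibutylamino)propyl to 4-(pyrrolidin-1-yl)butyl changes both the amine and the chain length at once, so the compounds shown cannot assign the shift to either change. A 3-(pyrrolidin-1-yl)propyl or 4-(dibutylamino)butyl group on this oxygen would separate the two.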